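Compound 1 to compound 4: an aryl swap in the tolerated range

A few compounds are considered here, and "the series" means these few. Any claim that something is new, unique, unknown or untested is made for them only; others in the source may bear on it.

Within the data shown here, in an ADME assay on THP-1 cells (Homo sapiens) for cytotoxicity, read by MTT assay (a higher number here means that more compound is tolerated, a lower number that less compound is tolerated), compound 1 `Fc1ccc(-c2nc(C(Cl)(Cl)Cl)nc3ccccc23)cc1` gives 500000 nM, the only number so far. Compound 2 `FC(F)(F)c1cccc(-c2nc(C(Cl)(Cl)Cl)nc3ccccc23)c1` reads > 500000 nM, which is a limit. Compound 3 `COc1ccc(-c2nc(C(Cl)(Cl)Cl)nc3ccccc23)cc1` reads > 250000 nM, which is also a limit.

The next compound to be measured is compound 4 `Cc1ccc(-c2nc(C(Cl)(Cl)Cl)nc3ccccc23)s1`, where 5-methylthiophen-2-yl replaces 4-fluorophenyl on an aromatic carbon, next to the ring nitrogen: 5-methylthiophen-2-yl in place of 4-fluorophenyl on an aromatic carbon.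

Among the measured compounds shown here, one measured step bears on this change, as it also alters the group on the aromatic ring: a step that the limit leaves unreadable from compound 1 to compound 3. For the measured compounds named here, it gives no size to carry over, and no measured step covers a thiophene. The expectation in this assay therefore rests on compound 1 at 500000 nM, and no step beyond the scatter is expected. The expected step is a 1.7-fold lower number from compound 1 to compound 4 (0.22 log units; within the scatter). For compound 4 the estimated value is 300000 nM, with an expected range from 100000 nM to 600000 nM. A report as a limit rather than a number would also be unsurprising.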

Compound 4, concentration lethal to 50% of the cells: 125000 nM
Compound 4: middle estimate off by 2.4-fold (0.38 log units), on the high side; the measured number falls inside the stated range.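

In this assay, among these compounds, the first readable step at this position is a 4.0-fold lower number from compound 1 to compound 4 (0.60 log units; beyond the scatter) and it is modest. The position next to the ring nitrogen therefore does respond to the aryl group: 5-methylthiophen-2-yl in place of 4-fluorophenyl gives a change that lies beyond the scatter. The earlier step here cannot be read, and compound 3 gives > 250000 nM as a limit, so this is the only size available for a change at this position.

The compounds shown do not separate the five-membered aromatic ring from its methyl group, and they leave open how an amine or a carboxylic acid on the aryl ring would read. Nothing measured here accounts for the step.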